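The source may report more compounds than this note shows. Statements on the series, on what has been measured and on what is new or still open speak of the compounds shown alone.

Measured compounds:
compound 1 `CCCCCCCCCCCCCCCCCC(=O)N1CCOCC1`, 42.8 ug/mL in a functional assay on MCF7 cells (Homo sapiens) for antiproliferative activity, read by sulforhodamine B assay, with a stated time of 48 h; a lower number here means a stronger inhibitor of growth, a higher number a weaker inhibitor of growth
compound 2 `CCCCCCCCCCCCCCCC(=O)N1CCCC1`, 4.6 ug/mL
compound 3 `CCCCCCCCCCCCCCCCCC(=O)N[C@H](C)c1ccccc1`, 0.06 ug/mL

Compound 3 gives the lowest number of the three in this assay; compound 2 lies nearest to it, and compound 1 lies furthest away. Among the measured compounds shown here, the one step measured between compounds that differ in a single place, a 710-fold lower number from compound 1 to compound 3 (2.85 log units; beyond the scatter), shows that the amide substituent on the carbonyl carbon governs this series strongly.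

Compound 4 `CCCCCCCCCCCCCCCCCC(=O)N1CCCC1` has not yet been measured. It differs from compound 3 by pyrrolidin-1-yl in place of (1-phenylethyl)amino on a carbonyl carbon. For the measured compounds named here, no measured step covers this exact change. The step from compound 1 to compound 3 bears on it indirectly, since compound 4 returns from the (1-phenylethyl)amino of compound 3 to a cyclic amide, and compound 2, which carries the same pyrrolidin-1-yl on its carbonyl carbon but a shorter saturated chain, gives 4.6 ug/mL. On that basis compound 4 is expected to sit near compound 2, well above compound 3 and somewhat below compound 1. The step from compound 3 to compound 4 is therefore expected to be large and upward, an 83-fold higher number from compound 3 to compound 4 (1.92 log units; beyond the scatter). Compound 4 is estimated at 5 ug/mL, with a range of 1.5 ug/mL to 20 ug/mL.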

Compound 4, concentration for 50% growth inhibition: 7.4 ug/mL
For compound 4 the middle estimate is 1.5-fold (0.17 log units) below the measured one; the range from low to high includes it.
By their numbers in this assay, from the lowest: compound 3; then compounds 2 and 4 (each within the scatter of the next); then compound 1.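

In this assay, with the chain held the same, a 120-fold higher number from compound 3 to compound 4 (2.09 log units; beyond the scatter) shows that the gap between compound 3 and the cyclic amides remains when pyrrolidin-1-yl is the entering group, so it does not depend on morpholin-4-yl alone. Within the cyclic amides, a 5.8-fold lower number from compound 1 to compound 4 (0.76 log units; beyond the scatter) is a much smaller step, so the choice of ring also counts, but far less than leaving (1-phenylethyl)amino. The chain makes no readable difference here, since a 1.6-fold higher number from compound 2 to compound 4 (0.21 log units; within the scatter) lies within the scatter.

From the compounds shown here alone, what remains open is which part of (1-phenylethyl)amino goes with the low number of compound 3: its phenyl ring, its methyl, its stereocentre or the amide hydrogen. Benzylamino, the mirror-image (1-phenylethyl)amino or a piperidin-1-yl amide would test this further. Nothing given here explains any of these steps.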